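The source may hold more compounds than are shown below. What is called first, only, known or untested is meant among the compounds shown, and "the series" means these compounds.

Working notes on the series. In a functional assay on A2780 cells (Homo sapiens) for antiproliferative activity, read by MTT assay, with a stated time of 48 h (a higher number here means a weaker inhibitor, a lower number a stronger inhibitor), compound 1 (`COc1ccc(C(=O)c2ccc3c(c2)C=CC(C)(C)O3)c(NC(=O)CBr)c1`) gives 1870 nM as its measured value, and compound 2 (`COc1ccc(C(=O)c2ccc(OC)c3c2C=CC(C)(C)O3)c(NC(=O)CO)c1`) gives 420 nM on the same read-out. Compound 1 therefore holds the higher of the two numbers, which makes it the weaker inhibitor of this pair, by a gap beyond the usual scatter. Compound 3 (`COc1ccc(C(=O)c2ccc3c(c2)C=CC(C)(C)O3)c(NC(=O)CN(C)C)c1`) has not yet been measured in this assay. It differs from compound 1 by one change (dimethylamino in place of bromo on a saturated chain carbon bound to a carbonyl carbon): dimethylamino in place of bromo on a saturated chain carbon bound to a carbonyl carbon. Going by the values given here, no pair of measured compounds isolates this change, so the expectation rests on very little. Among the compounds with values here, with compound 1 at 1870 nM as the higher of only two numbers, a modest move toward a lower number is expected rather than a further rise, though a result within the scatter would not surprise. The expected change is a 2.1-fold lower number from compound 1 to compound 3 (0.32 log units; beyond the scatter) with wide uncertainty. For compound 3 the estimate is 900 nM within an expected range of 200 nM to 4000 nM on this evidence.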

Compound 3, half-maximal inhibitory concentration: 1020 nM
For compound 3 the middle estimate is 1.1-fold (0.05 log units) below the measured one, within the range that was stated.
By their numbers in this assay, from the lowest: compound 2; then compounds 3 and 1 (each within the scatter of the next).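

In this assay, going by these compounds alone, the first readable step at this position, dimethylamino in place of bromo on a saturated chain carbon bound to a carbonyl carbon, gives a 1.8-fold lower number from compound 1 to compound 3 (0.26 log units; within the scatter). On the core of compound 1, the bromo can therefore be exchanged for dimethylamino, with three heavy atoms entering for one and a hydrogen-bond acceptor counted where the bromo has none, without a step beyond the scatter. No measurement shown explains this result or separates the contribution of the leaving group from that of the entering group.

The compounds shown leave open whether another group on this carbon, such as a primary amine, a carboxylic acid or a longer chain ending in dimethylamino, would give a step beyond the scatter. Within the data shown here, with only one step read here, they also leave open whether the exchange of bromo for dimethylamino would read the same on a core carrying a further methoxy group.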